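The source may report more compounds than this note shows. Statements on the series, on what has been measured and on what is new or still open speak of the compounds shown alone.

In an ADME assay on Raji cells (Homo sapiens) for cytotoxicity, with a stated time of 72 h (on this read-out higher numbers stand for an effect only at larger amounts of compound and lower numbers for an effect already at smaller amounts), compound 2 `O=C(Nc1cccc(-c2nc3ccccc3s2)c1)c1cc([N+](=O)[O-])ccc1Cl` gives only a limit, > 27000 nM. Compound 1 `O=C(Nc1cc(-c2nc3ccccc3s2)ccc1Cl)c1cc([N+](=O)[O-])ccc1Cl` likewise gives only a limit in this assay, > 25000 nM. For the measured compounds named here, the single step measured so far, a step that the two limits leave unreadable from compound 1 to compound 2, therefore has no readable size, since both its ends sit at limits, the limit of > 25000 nM in this assay, at which 1 of the 2 values shown sits, and (the limit of > 27000 nM in this assay, at which 1 of the 2 values shown sits). Compound 3 `O=C(Nc1cccc(-c2nc3ccccc3[nH]2)c1)c1cc([N+](=O)[O-])ccc1Cl` differs from compound 2 by 1H-benzimidazol-2-yl in place of 1,3-benzothiazol-2-yl on an aromatic carbon. Going by the values given here, no measured step covers this kind of change, and nothing here points to a direction. The expected value for compound 3 is 30000 nM, with a range from 8000 nM to 100000 nM. The estimated step that the limit leaves unreadable from compound 2 to compound 3 is thus expected to stay within the scatter.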

Compound 3, half-maximal effective concentration: 20700 nM
Compound 3: the middle estimate sits 1.4-fold (0.16 log units) above what was measured, within the range that was stated.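

In this assay, for the compounds shown here, putting 1H-benzimidazol-2-yl in place of 1,3-benzothiazol-2-yl on this aromatic carbon gives an at least 1.3-fold lower number from compound 2 to compound 3 (0.11 log units; that floor lies within the scatter) as the first step here with a readable size. Going by these compounds alone, compound 3 is also the first compound here to give a number rather than a limit, although the floor of this step does not by itself show a real change. Only a floor can be read, since compound 2 stands at a limit: the limit of > 27000 nM in this assay, at which 1 of the 3 values shown sits.

From the compounds shown here alone, whether an amine or a carboxylic acid on this carbon would give a lower number stays open. So does how 1H-benzimidazol-2-yl would behave on the core of compound 1.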